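Swapping the chlorophenyl on the chain of compound 2

A few compounds are considered here, and "the series" means these few. Any claim that something is new, unique, unknown or untested is made for them only; others in the source may bear on it.

Measured so far:
- compound 1 `Cc1nc(Nc2cccc(Cl)c2)sc1C(=O)/C=C/c1ccc(Cl)cc1`: > 25000 nM in a functional assay on BGC-823 cells (Homo sapiens) for cytotoxicity, read by MTT assay; on this read-out higher numbers stand for weaker inhibition and lower numbers for stronger inhibition
- compound 2 `Cc1ccccc1Nc1nc(C)c(C(=O)/C=C/c2ccccc2Cl)s1`: > 25000 nM in this assay

In this assay compound 1 returns only a limit of the assay, not a number. Compound 2 likewise returns only a limit in this assay. Both readings therefore rest at the limit of > 25000 nM in this assay, at which 2 of the 2 values shown sit, so compound 2 stands nowhere on a numerical scale: all that is known is that its inhibition is too weak to be resolved.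

Compound 3 `Cc1ccccc1Nc1nc(C)c(C(=O)/C=C/c2ccc(Cl)cc2)s1` differs from compound 2 in one place: 4-chlorophenyl in place of 2-chlorophenyl on a double-bonded chain carbon bound to a double-bonded chain carbon. Going by the values given here, no measured pair in this set isolates this change, but compound 1 already carries 4-chlorophenyl on the chain and gives > 25000 nM as a limit. For compound 3 the expected step that the limit leaves unreadable from compound 2 to compound 3 is none beyond the scatter, and the estimate for compound 3 in this assay is 35000 nM, within 12000 nM to 100000 nM, most probably reported again only as a limit.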

Compound 3, half-maximal inhibitory concentration: > 25000 nM
Compound 3 ended at the assay's limit; the forecaster's own chance of this, stated with the estimate: 85%; the middle value lies beyond the limit too.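

Compound 3 gives > 25000 nM in this assay, a limit of the assay and not a number. Going by these compounds alone, with compound 1 and compound 2 also at limits, no step to compound 3 can be read. The compounds shown leave open whether either change alters inhibition at all.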